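Pentyloxy in Place of Butyl on the Shared Core

A few compounds are considered here, and "the series" means these few. Any claim that something is new, unique, unknown or untested is made for them only; others in the source may bear on it.

Measured so far:
Compound 1 `CCCCc1ccc(-c2c(C)[nH]c(=O)n2C)cc1` — 10700 nM
Compound 2 `CCCCc1ccc(-c2c(C)[nH]c(=O)n2-c2ccccc2)cc1` — 16600 nM

Both compounds were tested in a functional assay on brain (Rattus norvegicus, strain Wistar) for inhibition; a higher number here means a weaker inhibitor, a lower number a stronger inhibitor. Compound 1 gives 10700 nM and compound 2 gives 16600 nM; the two numbers sit within the usual scatter of each other, so neither compound can be called the stronger inhibitor. For the measured compounds named here, the only measured step, a 1.6-fold higher number from compound 1 to compound 2 (0.19 log units; within the scatter), concerns the aromatic nitrogen and tells nothing about the other end of the molecule.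

Compound 3 `CCCCCOc1ccc(-c2c(C)[nH]c(=O)n2C)cc1` differs from compound 1 at that other end: pentyloxy in place of butyl on an aromatic carbon. Going by the values given here, no measured pair shows what a change at this aromatic carbon does in this assay, so the expectation rests on compound 1 alone, with no direction of change to lean on. Compound 3 is therefore expected to give a number close to that of compound 1, with a 1.1-fold lower number from compound 1 to compound 3 (0.03 log units; within the scatter) as the expected step and a wide range to reflect the missing evidence. The estimate for compound 3 is 10000 nM, from 3000 nM to 35000 nM.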

Compound 3, half-maximal inhibitory concentration: 4500 nM
Compound 3: middle estimate off by 2.2-fold (0.35 log units), on the high side; the measured number falls inside the stated range.
By their numbers in this assay, from the lowest: compound 3; then compounds 1 and 2 (each within the scatter of the next).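

For the compounds shown here, the step of a 2.4-fold lower number from compound 1 to compound 3 (0.38 log units; beyond the scatter) in this assay is the first measured change at this aromatic carbon, and it shows that the far end of the molecule can shift the number beyond the scatter. The earlier pair could not show this: phenyl in place of methyl on the aromatic nitrogen gave a 1.6-fold higher number from compound 1 to compound 2 (0.19 log units; within the scatter), a difference too small to separate the two compounds, while pentyloxy in place of butyl gives a modest but readable gain in inhibition. Nothing available speaks to why this swap lowers the number.

The swap changes two things at once, as it adds an oxygen and also alters the chain, so the compounds shown cannot say which of the two matters; a plain pentyl chain or a butoxy group on the same carbon would begin to separate them. As far as these compounds go, it also remains open whether a longer alkoxy chain, or an amine at this carbon, would lower the number further, and whether pentyloxy brings a similar step when phenyl sits on the aromatic nitrogen.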